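Adding a phenyl ring to the lactam of compound 3

This account rests on a few compounds, and the source may have more. Where it says the series, first, only, none or still open, it means among the compounds named here.

Measured compounds:
Compound 1 `O=C(CCCCC[C@H](NC(=O)[C@@H]1CCCC(=O)N1)C(=O)Nc1ccccc1)NO` gives 51 nM in an assay on isolated protein for inhibition of polyamine deacetylase HDAC10 (Homo sapiens), read by fluorescence; on this read-out higher numbers stand for weaker inhibition and lower numbers for stronger inhibition.
Compound 2 `O=C(CCCCC[C@H](NC(=O)C1CCCNC1=O)C(=O)Nc1ccccc1)NO` gives 244 nM in this assay.
Compound 3 `O=C(CCCCC[C@H](NC(=O)C1CCNC1=O)C(=O)Nc1ccccc1)NO` gives 147 nM in this assay.

Compound 3 stands second highest of the three numbers: there is a 1.7-fold lower number from compound 2 to compound 3 (0.22 log units; within the scatter), and there is a 2.9-fold higher number from compound 1 to compound 3 (0.46 log units; beyond the scatter). Compound 4 `O=C(CCCCC[C@H](NC(=O)C1C(=O)NCC1c1ccccc1)C(=O)Nc1ccccc1)NO` differs from compound 3 by phenyl in place of hydrogen on a saturated ring carbon. The measured steps only swap one lactam ring for another; none adds a group to a ring carbon, so they give no direct guide. A step within the usual scatter is therefore expected, a 1.0-fold higher number from compound 3 to compound 4 (0.01 log units; within the scatter). The expected value for compound 4 in this assay is 150 nM, between 50 nM and 450 nM.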

Compound 4, half-maximal inhibitory concentration: 88 nM
Beside the measured number, compound 4's estimate is 1.7-fold (0.23 log units) above it, within the range that was stated.
By their numbers in this assay, from the lowest: compounds 1, 4, 3 and 2 (each within the scatter of the next, the first and the last beyond it).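

In this assay, the saturated ring carbon two ring bonds from the ring nitrogen can carry a whole phenyl ring, with a 1.7-fold lower number from compound 3 to compound 4 (0.22 log units; within the scatter). Among the compounds shown here, compound 4 is the first compound here with a group added to a lactam ring carbon, and this large addition leaves the number within the scatter of the hydrogen-bearing compound. Nothing measured here gives a reason for this result.

As far as these compounds go, it remains open whether an amine, a carboxylic acid or a benzyl group on this carbon would read the same. From the compounds shown here alone, it is also open whether phenyl would be accepted on the 6-oxopiperidin-2-yl ring of compound 1.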